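The compounds below may be only part of what the source reports. "The series", "measured", "known", "first", "only" and "open" are said of these compounds alone.

Measured in a functional assay (strain AB) with Danio rerio as the target, read by microscopy, with a stated time of 1 h (on this read-out higher numbers stand for an effect only at larger amounts of compound and lower numbers for an effect already at smaller amounts), so far:
compound 1 `CC(C)(C)OC(=O)CCCCC[N+]1(C)CCc2c(sc(NC(=O)Nc3ccc(Cl)cc3)c2C(N)=O)C1`: 110 nM
compound 2 `CC(C)CN1CCc2c(sc(NC(=O)Nc3ccc(Cl)cc3)c2C(N)=O)C1`: 4510 nM

Of these two, compound 1 at 110 nM has the lower number, and compound 2 at 4510 nM lies above it by a gap beyond the usual scatter. Compound 3 `CC[N+]1(C)CCc2c(sc(NC(=O)Nc3ccc(Cl)cc3)c2C(N)=O)C1` has not yet been measured. It differs from compound 1 by a single change, (hydrogen in place of 3-(tert-butoxycarbonyl)propyl on a saturated chain carbon, two bonds along the chain from an amine nitrogen in a ring), with hydrogen in place of 3-(tert-butoxycarbonyl)propyl on a saturated chain carbon, two bonds along the chain from an amine nitrogen in a ring. For the measured compounds named here, no measured pair isolates this change, so the data give no direct size for it. In this assay a move to a higher number, beyond the scatter, is expected. Going by the values given here, this expectation rests on compound 1 at 110 nM holding the lowest number so far, while compound 2 at 4510 nM shows how much higher the shared core can read. The expected size of the move is a 7.3-fold higher number from compound 1 to compound 3 (0.86 log units; beyond the scatter) on this read-out. For compound 3 the estimated value is 800 nM, with an expected range from 130 nM to 5000 nM.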

Compound 3, half-maximal effective concentration: 1960 nM
For compound 3 the middle estimate is 2.5-fold (0.39 log units) below the measured one, within the range that was stated.
By their numbers in this assay, from the lowest: compound 1; then compound 3; then compound 2.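

In this assay, this step gives the first direct size for the position: with hydrogen in place of 3-(tert-butoxycarbonyl)propyl on a saturated chain carbon, two bonds along the chain from an amine nitrogen in a ring, the data show an 18-fold higher number from compound 1 to compound 3 (1.25 log units; beyond the scatter). Read one bond further out, the same difference is 4-(tert-butoxycarbonyl)butyl to methyl, so the long chain ending in the tert-butoxycarbonyl group accounts for a large part of the low number of compound 1, while compound 3 without it still reads 1960 nM. Nothing in the data shown explains the size of this step.

The step removes the chain length and the tert-butoxycarbonyl end together, so the compounds shown cannot say which of the two matters, or whether both do. A plain alkyl chain of similar length, the same chain ending in a carboxylic acid, or a shorter chain carrying the same tert-butoxycarbonyl end would be needed to separate these contributions at this position.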